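Removing a trifluoromethyl from compound 2

The source may report more compounds than this note shows. Statements on the series, on what has been measured and on what is new or still open speak of the compounds shown alone.

compound 1 (`COc1cc(-c2nn(-c3cccc(NC(=O)Nc4cc(C(F)(F)F)cc(C(F)(F)F)c4)c3)cc2-c2ccncc2)ccc1Cl`) gives 3710 nM in a functional assay on SK-MEL-2 cells (Homo sapiens) for inhibition, read by sulforhodamine B assay, with a stated time of 48 h; a lower number here means that less compound is tolerated, a higher number that more compound is tolerated
compound 2 (`COc1cc(-c2nn(-c3cccc(NC(=O)c4cccc(C(F)(F)F)c4)c3)cc2-c2ccncc2)ccc1Cl`) gives > 50000 nM in this assay

Compound 2 stands at > 50000 nM in this assay as a limit of the assay and not a number. Compound 3 (`COc1cc(-c2nn(-c3cccc(NC(=O)c4ccccc4)c3)cc2-c2ccncc2)ccc1Cl`) carries hydrogen in place of trifluoromethyl on an aromatic carbon, meta to a large group (hydrogen in place of trifluoromethyl on an aromatic carbon). Going by the values given here, no step between measured compounds is available to size this change, so no shift beyond the scatter is expected in either direction, and another limit is quite possible. The expected change is a number no higher from compound 2 to compound 3 (the limit leaves the size open) in this assay on this reading. Compound 3 is estimated at 50000 nM with an expected range of 25000 nM to 100000 nM in this assay here.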

Compound 3, concentration lethal to 50% of the cells: > 100000 nM
Compound 3: no number, only a limit (the forecaster's own chance of this, stated with the estimate: 70%); middle value at least 2.0-fold (0.30 log units) from the limit.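

Going by these compounds alone, compound 2 and compound 3 each stand only at a limit of the assay, so no step between them can be read. The compounds shown leave open whether hydrogen in place of trifluoromethyl shifts the value at all, and in which direction.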